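Urea-pyrimidine series: replacing pyrrolidinyl with cyclopropylamino

A few compounds are considered here, and "the series" means these few. Any claim that something is new, unique, unknown or untested is made for them only; others in the source may bear on it.

Measured compounds:
compound 1 `O=C(Nc1ccccc1)Nc1nc(NC2CC2)cc(Sc2c[nH]c3ccccc23)n1`, 14300 nM
compound 2 `Cc1cc(Cl)ccc1NC(=O)Nc1nc(Nc2ccccc2)cc(Sc2c[nH]c3ccccc23)n1`, 8370 nM
compound 3 `Cc1cc(Cl)ccc1NC(=O)Nc1nc(Sc2c[nH]c3ccccc23)cc(N2CCCC2)n1`, 7150 nM

All three were run in a functional assay on HepG2 cells (Homo sapiens) for inhibition, with a stated time of 72 h; on this read-out higher numbers stand for weaker inhibition and lower numbers for stronger inhibition. Compound 3 holds the lowest of the three numbers, but its gap to compound 2 and its gap to compound 1 are both within the scatter, so no ranking among them can be claimed. Within the data shown here, the only single-point step among the measured compounds is a 1.2-fold lower number from compound 2 to compound 3 (0.07 log units; within the scatter), which did not move the read-out beyond the scatter.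

Compound 4 `Cc1cc(Cl)ccc1NC(=O)Nc1nc(NC2CC2)cc(Sc2c[nH]c3ccccc23)n1` has not yet been measured. It differs from compound 3 by cyclopropylamino in place of pyrrolidin-1-yl on an aromatic carbon. Among the measured compounds shown here, no measured pair isolates this exact change: compound 1 carries the cyclopropylamino group but also a different urea aryl part, so its value and that of compound 3 can only be compared as two numbers that sit within the scatter of each other. For the measured compounds named here, the one step that bears on variation at this aromatic carbon, from compound 2 to compound 3, was within the scatter. The expected step for compound 4 is therefore a 1.2-fold higher number from compound 3 to compound 4 (0.08 log units; within the scatter), with no change beyond the scatter in either direction. Compound 4 is estimated at 8500 nM in this assay, in a range from 3500 nM to 20000 nM.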

Compound 4, half-maximal inhibitory concentration: 9740 nM
For compound 4 the middle estimate is 1.1-fold (0.06 log units) below the measured one; the measured number falls inside the stated range.
By their numbers in this assay, from the lowest: compounds 3, 2, 4 and 1 (each within the scatter of the next).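

In this assay, the change at this aromatic carbon can now be read as a matched pair: cyclopropylamino in place of pyrrolidin-1-yl gives a 1.4-fold higher number from compound 3 to compound 4 (0.13 log units; within the scatter), so the hydrogen-bond donor that enters with cyclopropylamino comes with no move beyond the scatter. Among these compounds, with the 4-chloro-2-methylphenyl urea part held, cyclopropyl in place of phenyl on the nitrogen gives a 1.2-fold higher number from compound 2 to compound 4 (0.07 log units; within the scatter), and with cyclopropylamino held, 4-chloro-2-methylphenyl in place of phenyl on the amide-type nitrogen gives a 1.5-fold lower number from compound 1 to compound 4 (0.17 log units; within the scatter), which is the first reading of the urea aryl part on its own, so anilino, pyrrolidin-1-yl and cyclopropylamino at this carbon and both urea aryl groups all stay within the scatter of one another. Nothing at hand bears on what lies behind these small steps.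

Open, as far as these compounds go, is whether a morpholin-4-yl, a dimethylamino or a longer chain ending in a carboxylic acid at this aromatic carbon would move the number beyond the scatter. Also open is what a change to the (1H-indol-3-yl)sulfanyl group would do, as all the compounds shown carry it unchanged.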